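The source may report more compounds than this note shows. Statements on the series, on what has been measured and on what is new or still open speak of the compounds shown alone.

Three compounds measured in a functional assay on HT-29 cells (Homo sapiens) (a lower number here means a stronger inhibitor of growth, a higher number a weaker inhibitor of growth), gave these values:

Compound 1 (`CC(C)(C)c1cc(/C=C/S(=O)(=O)Cc2ccc(Nc3ncnc4ccccc34)cc2)cc(C(C)(C)C)c1O`): 17000 nM
Compound 2 (`O=S(=O)(/C=C/c1ccc(F)cc1F)Cc1ccc(Nc2ncnc3cc(Cl)ccc23)cc1`): > 100000 nM as a limit of the assay
Compound 3 (`COc1cc2ncnc(Nc3ccc(CS(=O)(=O)/C=C/c4ccc(Cl)cc4Cl)cc3)c2cc1OC`): 6000 nM

Compound 3 holds the lowest number, and compound 1 is its nearest neighbour, with a gap beyond the scatter. Compound 4 (`COc1cc2ncnc(Nc3ccc(CS(=O)(=O)/C=C/c4ccc(Br)cc4)cc3)c2cc1OC`) differs from compound 3 in one place (4-bromophenyl in place of 2,4-dichlorophenyl on a double-bonded chain carbon bound to a double-bonded chain carbon), with 4-bromophenyl in place of 2,4-dichlorophenyl on a double-bonded chain carbon bound to a double-bonded chain carbon. Going by the values given here, no pair of measured compounds isolates this change. Compound 4 keeps the core of compound 3 (6000 nM), so that value is the anchor, and no step beyond the scatter is expected. The expected change is slight and towards weaker inhibition (a 1.3-fold higher number from compound 3 to compound 4 (0.12 log units; within the scatter)). The estimate for compound 4 is 8000 nM (expected range 2500 nM to 30000 nM).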

Compound 4, concentration for 50% growth inhibition: 24000 nM
For compound 4 the middle estimate is 3.0-fold (0.48 log units) below the measured one; the range from low to high includes it.
By their numbers in this assay, from the lowest: compound 3; then compounds 1 and 4 (each within the scatter of the next). At a limit, above all of these: compound 2.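

In this assay, going by these compounds alone, exchanging the 2,4-dichlorophenyl group for a 4-bromophenyl group gives a 4.0-fold higher number from compound 3 to compound 4 (0.60 log units; beyond the scatter) and is the only change at this position that can be read on a shared core. The group here therefore matters to the read-out, as this swap alone moves the number beyond the scatter. Nothing shown gives a cause for this step.

On these data alone, what a 4-chlorophenyl group, or a phenyl group carrying an amine, would do at this place remains open. So does whether the step would hold on the core of compound 1.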